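This account rests on a few compounds, and the source may have more. Where it says the series, first, only, none or still open, it means among the compounds named here.

Among the compounds with values here, in an ADME assay on cells (spleen, Mus musculus, strain C57BL/6) for inhibition, read by flow cytometry and propidium iodide staining, with a stated time of 24 h, at 37 degrees C (on this read-out higher numbers stand for an effect only at larger amounts of compound and lower numbers for an effect already at smaller amounts), compound 1 `CC(C)(O)c1cn(CC(=O)NCc2ccccc2)nn1` gives 1600 uM and compound 2 `Nc1cccc(-c2cn(CC(=O)NCc3ccccc3)nn2)c1` gives 800 uM as the only numbers so far. These two values lie within the scatter of each other, so compound 2 stands level with compound 1 and cannot be set apart from it. Compound 3 `O=C(Cn1cc(-c2cccc(C(F)(F)F)c2)nn1)NCc1ccccc1` differs from compound 2 by trifluoromethyl in place of amino on an aromatic carbon, meta to a large group. Within the data shown here, the only measured step (a 2.0-fold lower number from compound 1 to compound 2 (0.30 log units; within the scatter)) put 3-aminophenyl in place of 1-hydroxy-1-methylethyl on an aromatic carbon. Among the measured compounds shown here, it does not test the present change directly, and no measured compound yet carries trifluoromethyl. Still, that exchange of a whole group stayed within the scatter, so a step beyond the scatter is not expected in this assay here, and no firm direction can be given. The estimated step (a 1.3-fold lower number from compound 2 to compound 3 (0.12 log units; within the scatter)) accordingly stays within the scatter. Compound 3 is expected at 600 uM in a range from 200 uM to 1600 uM in this estimate.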

Compound 3, concentration for half-maximal effect: "non-toxic" (no number reported)
Compound 3: no number reported; the estimate stays without a comparison.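

In this assay, within the data shown here, compound 3 is reported as "non-toxic" with no number, so no step from compound 2 to compound 3 can be read. Nothing measured here bears on this result. The compounds shown leave open how trifluoromethyl in place of amino would shift the number on this read-out.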